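One Trifluorophenyl Group for Another

This account rests on a few compounds, and the source may have more. Where it says the series, first, only, none or still open, it means among the compounds named here.

Compound 1 `OC[C@H]1O[C@@H](n2cnc3c(NCc4cccc(Br)c4)ncnc32)[C@H](O)[C@@H]1O`: 19700 nM
Compound 2 `OC[C@H]1O[C@@H](n2cnc3c(NCc4ccc(F)c(F)c4F)ncnc32)[C@H](O)[C@@H]1O`: > 166000 nM (a limit, not a number)

Both values come from a functional assay on K562 cells (Homo sapiens) for antiproliferative activity, with a stated time of 72 h (a higher number here means a weaker inhibitor, a lower number a stronger inhibitor), and the two compounds share one core. Compound 2 stands at the limit of > 166000 nM in this assay, at which 1 of the 2 values shown sits, and this is a limit of the assay, not a number. Still unmeasured is compound 3 `OC[C@H]1O[C@@H](n2cnc3c(NCc4c(F)ccc(F)c4F)ncnc32)[C@H](O)[C@@H]1O` in which 2,3,6-trifluorophenyl takes the place of 2,3,4-trifluorophenyl. The difference is counted here: 2,3,6-trifluorophenyl in place of 2,3,4-trifluorophenyl on a saturated chain carbon bound to a nitrogen on an aromatic ring on the same saturated chain carbon. Going by the values given here, only one measured step bears on this change: an at least 8.4-fold higher number from compound 1 to compound 2 (0.92 log units; beyond the scatter) is beyond the scatter and came with 2,3,4-trifluorophenyl replacing 3-bromophenyl. Among the compounds with values here, no measured step compares two trifluorophenyl groups. Within the data shown here, with an at least 8.4-fold higher number from compound 1 to compound 2 (0.92 log units; beyond the scatter) as the only guide, compound 3 is expected to remain weak, and no change beyond the scatter is expected. The estimated step is an at least 1.2-fold lower number from compound 2 to compound 3 (0.10 log units; that floor lies within the scatter) in this assay overall. Compound 3 is expected at 130000 nM with an estimated range from 40000 nM to 400000 nM as its likely span.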

Compound 3, half-maximal inhibitory concentration: > 166000 nM
Compound 3: only a limit was reported; the forecaster's own chance of this, stated with the estimate: 60%; at least 1.2-fold (0.10 log units) between middle value and limit.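

In this assay compound 3 also gives only a limit of the assay, not a number: the limit of > 166000 nM in this assay, at which 2 of the 3 values shown sit.

Against 3-bromophenyl, 2,3,6-trifluorophenyl on the same saturated chain carbon gives an at least 8.4-fold higher number from compound 1 to compound 3 (0.92 log units; beyond the scatter), so the loss seen with 2,3,4-trifluorophenyl is not tied to that one arrangement of the three fluorines. The step from compound 2 to compound 3 cannot be read, with a limit at both ends, so the two trifluorophenyl groups cannot be ranked.

The compounds shown leave open whether the loss follows the three fluorines or the absence of bromine: 3-chlorophenyl, 3-fluorophenyl or plain phenyl on that carbon could separate these readings. They also leave open whether any other trifluorophenyl arrangement gives a readable value in this assay.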